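The source may hold more compounds than are shown below. What is called first, only, known or untested is meant among the compounds shown, and "the series" means these compounds.

Values in a functional assay on OCI-Ly3 cells (Homo sapiens) for inhibition, read by CellTiter-Glo, with stated times of 48 h and 96 h; a lower number here means a stronger inhibitor of growth, a higher number a weaker inhibitor of growth:
compound 1 `CC(C)[C@H](NC(=O)c1ccc(Br)cc1)C(=O)N1CCC[C@H]1C(=O)N[C@@H](CCCNC(=N)N)C(=O)CF`: 130 nM
compound 2 `CC[C@H](C)[C@H](NC(=O)OCc1ccccc1)C(=O)N1CCC[C@H]1C(=O)N[C@@H](CCCNC(=N)N)C(=O)CF`: 2440 nM
compound 3 `N=C(N)NCCC[C@H](NC(=O)[C@@H]1CCCN1C(=O)[C@@H](NC(=O)OCc1ccccc1)C1CCCCC1)C(=O)CF`: 1450 nM
compound 4 `N=C(N)NCCC[C@H](NC(=O)[C@@H]1CCCN1C(=O)[C@@H](NC(=O)c1ccc(Br)cc1)C1CCCCC1)C(=O)CF`: not yet measured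

In this assay, compound 3 at 1450 nM lies within the scatter of compound 2 at 2440 nM. Compound 1 at 130 nM gives a number well below both.

The change under consideration is 4-bromophenyl in place of benzyloxy on a carbonyl carbon. Within the data shown here, no measured step isolates this exchange. Among the measured compounds shown here, the only measured step, a 1.7-fold lower number from compound 2 to compound 3 (0.23 log units; within the scatter), concerns cyclohexyl in place of sec-butyl at the other varied place, so cyclohexyl is not expected to cost much on its own. Compound 1 at 130 nM already carries 4-bromophenyl, but it also differs from compound 3 at that other place, so it is only an indirect guide. A drop close to the gap between those two values is therefore expected, though with wide uncertainty. The expected change is a 9.7-fold lower number from compound 3 to compound 4 (0.99 log units; beyond the scatter), which would lie beyond the scatter. For compound 4 the estimate is 150 nM, with an expected range of 50 nM to 500 nM.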

Compound 4, concentration for 50% growth inhibition: 130 nM
Estimate against measurement, compound 4: 1.2-fold (0.06 log units) above; the range from low to high includes it.
By their numbers in this assay, from the lowest: compounds 1 and 4 (each within the scatter of the next); then compounds 3 and 2 (each within the scatter of the next).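

In this assay, the exchange of benzyloxy for 4-bromophenyl on a carbonyl carbon now stands isolated, with an 11-fold lower number from compound 3 to compound 4 (1.05 log units; beyond the scatter) while the rest of the structure stays the same. The place on the saturated chain carbon remains tolerant with 4-bromophenyl present, as no change at the digits printed from compound 1 to compound 4 (within the scatter) for cyclohexyl in place of isopropyl matches a 1.7-fold lower number from compound 2 to compound 3 (0.23 log units; within the scatter) seen with benzyloxy present. Nothing measured here bears on why the carbonyl substituent matters so much more in this series.

As far as these compounds go, whether the bromine itself is required remains open, and plain phenyl, 4-chlorophenyl or 4-aminophenyl on the same carbonyl carbon would test this. From the compounds shown here alone, it is also open whether the tolerance on the chain carbon extends to a methyl group or to a chain ending in an amine.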